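Chloro on the fused ring: compound 2 to compound 3

This account rests on a few compounds, and the source may have more. Where it says the series, first, only, none or still open, it means among the compounds named here.

Both measured members of this series are weak growth inhibitors in a functional assay on cells (Leukemia cell, Homo sapiens) for cytotoxicity, read by sulforhodamine B assay, with a stated time of 48 h; a higher number here means a weaker inhibitor of growth, a lower number a stronger inhibitor of growth. Compound 1 `COc1ccc(C2=NN(C3=NC(=O)/C(=C4\C(=O)Nc5ccc(Cl)cc54)S3)C(c3ccc(OC)cc3)C2)cc1` gives 75200 nM in this assay. Compound 2 `COc1ccc(C2=NN(C3=NC(=O)/C(=C4\C(=O)Nc5ccccc54)S3)C(c3ccc(Cl)cc3)C2)cc1` gives 90900 nM in this assay, the higher of the two numbers, but its gap to compound 1 lies within the scatter, so the two values cannot be told apart. Compound 3 `COc1ccc(C2=NN(C3=NC(=O)/C(=C4\C(=O)Nc5ccc(Cl)cc54)S3)C(c3ccc(Cl)cc3)C2)cc1` has yet to be measured in this assay. It differs from compound 2 in one place: chloro in place of hydrogen on an aromatic carbon, on an aromatic carbon of a six-membered aromatic ring of carbon only, part of a fused or bridged system of two rings, meta to a fused ring and para to a fused ring. Within the data shown here, no pair of measured compounds differing in only one place exists here, so the size of this step cannot be read from a neighbour. A step of no more than the scatter, in either direction, is expected, because compound 1 already carries chloro on the fused system and gives 75200 nM, close to compound 2. The estimate for compound 3 is 80000 nM, with a range from 40000 nM to 160000 nM. The expected step is a 1.1-fold lower number from compound 2 to compound 3 (0.06 log units; within the scatter), within the scatter.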

Compound 3, concentration for total growth inhibition: 890 nM
Estimate against measurement, compound 3: 90-fold (1.95 log units) above, and the stated range ends above it.
By their numbers in this assay, from the lowest: compound 3; then compounds 1 and 2 (each within the scatter of the next).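

In this assay, chloro in place of hydrogen on an aromatic carbon of the fused system of two rings gives a 100-fold lower number from compound 2 to compound 3 (2.01 log units; beyond the scatter), so this position, silent in the earlier values, can carry a large change in growth inhibition. The second change to the same compound, chloro in place of methoxy on an aromatic carbon, gives an 84-fold lower number from compound 1 to compound 3 (1.93 log units; beyond the scatter), which shows that a chloro at the fused position does not by itself give the low number: compound 1 carries that chloro alongside methoxy and stays weak, and only compound 3, with both chloro groups, reaches the low value. Nothing measured here accounts for the size of either step.

The compounds shown leave open whether the gain belongs to chloro itself or would also appear with bromo, methyl or an amine on the same aromatic carbon of the fused system. As far as these compounds go, they also leave open how the analogue with hydrogen on the fused system and methoxy on both other aromatic rings would stand, so the separate share of each chloro remains unknown.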